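Benzyloxy Replaces Methyl on a Shared Core

The compounds below may be only part of what the source reports. "The series", "measured", "known", "first", "only" and "open" are said of these compounds alone.

Three compounds have been measured in an ADME assay on L6 cells (Rattus norvegicus) for cytotoxicity, read by resazurin assay, with a stated time of 72 h; on this read-out higher numbers stand for weaker inhibition and lower numbers for stronger inhibition:
compound 1 `Cc1ccc(C(=O)NC(=O)c2ccccc2O)cc1` gives 46 ug/mL
compound 2 `O=C(NC(=O)c1ccccc1O)c1ccc(OC(F)(F)F)cc1` gives 84 ug/mL
compound 3 `COC(=O)c1ccc(C(=O)NC(=O)c2ccccc2O)cc1` gives 42 ug/mL

Compound 1 stands second highest of these three numbers. Its steps to the others, a 1.1-fold lower number from compound 1 to compound 3 (0.04 log units; within the scatter) and a 1.8-fold higher number from compound 1 to compound 2 (0.26 log units; within the scatter), are both within the scatter, as is the step of a 2.0-fold lower number from compound 2 to compound 3 (0.30 log units; within the scatter). Compound 4 `O=C(NC(=O)c1ccccc1O)c1ccc(OCc2ccccc2)cc1` differs from compound 1 by benzyloxy in place of methyl on an aromatic carbon. For the measured compounds named here, none of the measured steps brings in a group as large as benzyloxy, so they bear on this change only loosely; each exchange at this position so far left this assay within the scatter. The step to compound 4 is therefore expected to be a 1.1-fold higher number from compound 1 to compound 4 (0.04 log units; within the scatter), with no direction beyond the scatter. Compound 4 is estimated at 50 ug/mL, between 20 ug/mL and 130 ug/mL.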

Compound 4, half-maximal inhibitory concentration: 64 ug/mL
Beside the measured number, compound 4's estimate is 1.3-fold (0.11 log units) below it; the range from low to high includes it.
By their numbers in this assay, from the lowest: compounds 3, 1, 4 and 2 (each within the scatter of the next).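

Even benzyloxy, which brings in a six-membered aromatic ring and is far larger than the methyl it replaces, does not move the number beyond the scatter in this assay: the result is a 1.4-fold higher number from compound 1 to compound 4 (0.14 log units; within the scatter) and a 1.5-fold higher number from compound 3 to compound 4 (0.18 log units; within the scatter) and also a 1.3-fold lower number from compound 2 to compound 4 (0.12 log units; within the scatter) as well. For the compounds shown here, all four groups at this position therefore give numbers within the scatter of one another, so group size shows no effect across these compounds. No supporting measurement is available to explain this result.

As far as these compounds go, whether an amine or a carboxylic acid at this position would shift the number beyond the scatter remains open. So does the effect of changes elsewhere on the shared core.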